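This account rests on a few compounds, and the source may have more. Where it says the series, first, only, none or still open, it means among the compounds named here.

In a functional assay on RAW264.7 cells (Mus musculus) for inhibition, read by fluorescence, with stated times of 1 h, 24 h and 30 min (on this read-out lower numbers stand for stronger inhibition and higher numbers for weaker inhibition), compound 3 `O=C(/C=C/c1ccccc1C(F)(F)F)c1cccc(O)c1` gives only a limit, > 10000 nM. Compound 2 `O=C(/C=C/c1ccccc1C(F)(F)F)c1ccccc1` also gives only a limit, > 10000 nM. Among the measured compounds shown here, the series so far stands at the limit of > 10000 nM in this assay, at which 3 of the 3 values shown sit. Compound 4 `O=C(/C=C/c1ccccc1C(F)(F)F)c1ccc(O)cc1` differs from compound 3 by 4-hydroxyphenyl in place of 3-hydroxyphenyl on a carbonyl carbon, with 4-hydroxyphenyl in place of 3-hydroxyphenyl on a carbonyl carbon. For the measured compounds named here, the one measured step that bears on this change is a step that the two limits leave unreadable from compound 2 to compound 3, so it offers no size to carry over. Compound 1 `O=C(/C=C/c1ccccc1F)c1ccc(O)cc1`, which also bears 4-hydroxyphenyl on a carbonyl carbon, gives only a limit, > 10000 nM. The estimated outcome is a number no higher from compound 3 to compound 4 (the limit leaves the size open), with no change beyond the scatter expected in this assay. For compound 4 the estimated value is 10000 nM, with an expected range from 3000 nM to 30000 nM.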

Compound 4, half-maximal inhibitory concentration: > 10000 nM
Compound 4: only a limit was reported; the forecaster's own chance of this, stated with the estimate: 70%; the middle value sits exactly at the limit.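

In this assay no step can be read from compound 1, compound 2 or compound 3 to compound 4, since each pair has only limits. The compounds shown leave open how strongly any of them inhibits, and whether 4-hydroxyphenyl and 3-hydroxyphenyl differ at all: the limit of > 10000 nM in this assay, at which 4 of the 4 values shown sit.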